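This account rests on a few compounds, and the source may have more. Where it says the series, first, only, none or still open, it means among the compounds named here.

Values measured in an ADME assay on H9c2 cells (Rattus norvegicus) for cytotoxicity, read by resazurin assay, with a stated time of 72 h; a lower number here means that less compound is tolerated, a higher number that more compound is tolerated:
- Compound 1 `C/C(=N\Nc1nc(-c2ccccc2)cs1)c1ccc(Cl)c(Cl)c1` gives > 50000 nM (a limit)
- Compound 2 `C/C(=N\Nc1nc(-c2ccncc2)cs1)c1ccc(Cl)c(Cl)c1` gives 41900 nM (a number)
- Compound 3 `C/C(=N\Nc1nc(-c2ccc(C)cc2)cs1)c1ccc(Cl)c(Cl)c1` gives > 50000 nM (a limit)

Compound 3 thus stands on a limit (> 50000 nM) and not on a number. Compound 4 `C/C(=N\Nc1nc(-c2ccc(Br)cc2)cs1)c1ccc(Cl)c(Cl)c1` has bromo in place of methyl on an aromatic carbon, para to a large group bromo in place of methyl on an aromatic carbon and is otherwise the same as compound 3.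

Among the compounds with values here, three measured steps bear on this change. They are a step that the two limits leave unreadable from compound 1 to compound 3 and an at least 1.1-fold lower number from compound 1 to compound 2 (0.07 log units; that floor lies within the scatter) and also an at least 1.1-fold higher number from compound 2 to compound 3 (0.07 log units; that floor lies within the scatter) in this small set. None shows a readable change beyond the scatter, so no step beyond the scatter is expected in this assay because the limit of > 50000 nM in this assay, at which 2 of the 3 values shown sit, is where this series mostly sits. The expected outcome is a number no higher from compound 3 to compound 4 (the limit leaves the size open) and nothing larger. Compound 4 is estimated at 50000 nM with an expected range from 25000 nM to 80000 nM and may again stand on a limit.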

Compound 4, half-maximal cytotoxic concentration: > 50000 nM
Compound 4 gave a limit, no number; the forecaster's own chance of this, stated with the estimate: 65%; the middle value lies on the limit itself.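

In this assay compound 4 gives > 50000 nM, which is a limit and not a number. Bromo at this position shows an at least 1.1-fold higher number from compound 2 to compound 4 (0.07 log units; that floor lies within the scatter), while the other two new steps join two limits and cannot be read. A third substituent on this phenyl position thus ends at the same limit, and the series gathers there: the limit of > 50000 nM in this assay, at which 3 of the 4 values shown sit.

From the compounds shown here alone, what an amine or a carboxylic acid in place of bromo would do remains open. So does any order among compound 1, compound 3 and compound 4.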